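The source may hold more compounds than are shown below. What is called first, only, known or untested is meant among the compounds shown, and "the series" means these compounds.

Measured so far:
compound 1 `O=C(NCc1ccc(F)cc1)c1nc(Br)c2cccnc2c1NCc1ccccc1` — "not determined" (no result reported) in a toxicity assay on C8166 cells (Homo sapiens) for cytotoxicity, read by MTT assay, with a stated time of 72 h; on this read-out lower numbers stand for higher toxicity in this test and higher numbers for lower toxicity in this test
compound 2 `CS(=O)(=O)NCCCN(c1nc(C(=O)NCc2ccc(F)cc2)c(O)c2ncccc12)S(C)(=O)=O` — 64000 nM

Among the measured compounds shown here, compound 2 is the only compound with a number in this assay; compound 1 carries no result there. Compound 3 `CS(=O)(=O)NCCCCCCN(c1nc(C(=O)NCc2ccc(F)cc2)c(O)c2ncccc12)S(C)(=O)=O` differs from compound 2 as follows: 3-(methanesulfonamido)propyl in place of methanesulfonamido on a saturated chain carbon, three bonds along the chain from a sulfonamide nitrogen. No measured pair with a single change is available, so the size of the step cannot be read from shown data. In this assay the step of a 1.3-fold lower number from compound 2 to compound 3 (0.11 log units; within the scatter) is expected to stay within the scatter, possibly leaning toward higher toxicity. Compound 3 is estimated at 50000 nM, range 20000 nM to 120000 nM.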

Compound 3, half-maximal cytotoxic concentration: 37000 nM
Compound 3: middle estimate off by 1.4-fold (0.13 log units), on the high side; the range from low to high includes it.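

In this assay the swap of methanesulfonamido for 3-(methanesulfonamido)propyl, on a saturated chain carbon three bonds along the chain from a sulfonamide nitrogen, gives a 1.7-fold lower number from compound 2 to compound 3 (0.24 log units; within the scatter) and so does not separate the two compounds. At this position, the 6-(methanesulfonamido)hexyl chain of compound 3 and the shorter chain of compound 2 therefore read alike in this test. No supporting data bear on this result.

Still open, on these data alone, is whether a longer chain would give a step beyond the scatter. The same question holds for an amine or a carboxylic acid in place of methanesulfonamido.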